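Working notes: benzothiazole swap on compound 1

This account rests on a few compounds, and the source may have more. Where it says the series, first, only, none or still open, it means among the compounds named here.

Measured in a functional assay on HeLa cells (Homo sapiens) for antiproliferative activity, read by MTT assay, with a stated time of 48 h; on this read-out lower numbers stand for stronger inhibition and higher numbers for weaker inhibition:
- Compound 1 `CN(C)CCCn1c(N)c(-c2nc3ccccc3[nH]2)c2nc(C#N)c(C#N)nc21`: 25900 nM
- Compound 2 `CCCCn1c(N)c(-c2nc3ccccc3[nH]2)c2nc(C#N)c(C#N)nc21`: > 50000 nM

Within the data shown here, compound 1 holds the only numeric value in this assay, at 25900 nM. The reading for compound 2, > 50000 nM, is a limit and not a number.

Compound 3 `CN(C)CCCn1c(N)c(-c2nc3ccccc3s2)c2nc(C#N)c(C#N)nc21` keeps the core of compound 1 and its 3-(dimethylamino)propyl group, and changes one substituent: 1,3-benzothiazol-2-yl in place of 1H-benzimidazol-2-yl on an aromatic carbon. Among the measured compounds shown here, the only measured step, an at least 1.9-fold higher number from compound 1 to compound 2 (0.28 log units; that floor lies within the scatter), lies on the chain and not at this place, so it gives no size for the swap. For the measured compounds named here, no measured step bears directly on this change, and no shift beyond the scatter in this assay is expected in either direction. The expected step is a 1.1-fold higher number from compound 1 to compound 3 (0.03 log units; within the scatter). Compound 3 is estimated at 28000 nM, with an expected range from 12000 nM to 50000 nM.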

Compound 3, half-maximal inhibitory concentration: 720 nM
For compound 3 the middle estimate is 39-fold (1.59 log units) above the measured one; measured number outside the range, below it.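

In this assay, the swap at this aromatic carbon gives a 36-fold lower number from compound 1 to compound 3 (1.56 log units; beyond the scatter), so the position is far from neutral in this series. The two groups match in heavy atoms and ring types and differ in one nitrogen against one sulfur and in their donor and acceptor counts, so a change of this limited kind is enough for a large step. Compound 2 holds a limit and not a number, so the new step is the only one here with a size read between two numbers: the limit of > 50000 nM in this assay, at which 1 of the 3 values shown sits.

Going by these compounds, whether the sulfur or the loss of the donor carries the step stays open, and a 1-methylbenzimidazol-2-yl or 1,3-benzoxazol-2-yl group at this place would help separate the two. Also open, on these data alone, is whether the step holds with the chain of compound 2.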